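From 3-Chlorophenyl to 4-Aminophenyl on a Shared Core

The source may report more compounds than this note shows. Statements on the series, on what has been measured and on what is new or still open speak of the compounds shown alone.

Measured in an assay for binding affinity to dual specificity mitogen-activated protein kinase kinase 4 (Homo sapiens), read by KINOMEscan, tested at 100 nM; on this read-out lower numbers stand for a stronger effect and higher numbers for a weaker effect at the one concentration tested:
compound 1 `CCCS(=O)(=O)Nc1ccc(F)c(C(=O)c2n[nH]c3ncc(-c4ccccc4)cc23)c1F` gives 2.4%
compound 2 `CCCS(=O)(=O)Nc1ccc(F)c(C(=O)c2n[nH]c3ncc(-c4cccc(Cl)c4)cc23)c1F` gives 40%
compound 3 `CCCS(=O)(=O)Nc1ccc(F)c(C(=O)c2n[nH]c3ncc(-c4ccccc4F)cc23)c1F` gives 2%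

Compound 2 stands highest of the three numbers; its nearest neighbour is compound 1, and the step of a number 37.6 percentage points higher from compound 1 to compound 2 (beyond the scatter) came with chloro in place of hydrogen on an aromatic carbon. Compound 4 `CCCS(=O)(=O)Nc1ccc(F)c(C(=O)c2n[nH]c3ncc(-c4ccc(N)cc4)cc23)c1F` is not yet measured. It differs from compound 2 as follows: 4-aminophenyl in place of 3-chlorophenyl on an aromatic carbon. The step of a number 38 percentage points lower from compound 2 to compound 3 (beyond the scatter) bears most directly on this change, as it also swaps out the 3-chlorophenyl, and a number 0.4 percentage points lower from compound 1 to compound 3 (within the scatter) shows the two other aryl groups sit close together. A large downward step a number 32 percentage points lower from compound 2 to compound 4 (beyond the scatter) is therefore expected in this assay . Compound 4 is estimated at 8%, between 1% and 35%.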

Compound 4, a percentage reported as activity, at one concentration (the size of the read-out at that concentration, not a potency): 0.1%
Compound 4: the middle estimate sits 7.9 percentage points above what was measured; measured number below the stated range.
By their numbers in this assay, from the lowest: compounds 4, 3 and 1 (each within the scatter of the next); then compound 2.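

In this assay, the 4-aminophenyl group, like the 2-fluorophenyl group, takes the number far down from that of the 3-chlorophenyl group (a number 39.9 percentage points lower from compound 2 to compound 4 (beyond the scatter)). Amino on the phenyl ring thus leaves the number where the unsubstituted phenyl has it (a number 2.3 percentage points lower from compound 1 to compound 4 (within the scatter)), and the two substituted phenyls do not separate (a number 1.9 percentage points lower from compound 3 to compound 4 (within the scatter)), so of the four compounds only compound 2 stands apart. Nothing measured here explains why the 3-chlorophenyl group behaves differently. Still open, as far as these compounds go, is whether the chloro itself or its place on the ring sets compound 2 apart. A methoxy group or a carboxylic acid on the same phenyl ring could also behave differently from the amino group.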